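Aryl to cyclohexyl on the amidine nitrogen of compound 1

A few compounds are considered here, and "the series" means these few. Any claim that something is new, unique, unknown or untested is made for them only; others in the source may bear on it.

Measured compounds in a functional assay on MCF7 cells (Homo sapiens) for cytotoxicity, read by MTT assay, with a stated time of 48 h; on this read-out lower numbers stand for stronger inhibition and higher numbers for weaker inhibition:
compound 1 `COc1ccc(N/C(CCNC2=CC(=O)c3ccccc3C2=O)=N\S(=O)(=O)c2ccc(C)cc2)cc1` gives 6030 nM
compound 2 `Cc1ccc(S(=O)(=O)/N=C(/CCNC2=CC(=O)c3ccccc3C2=O)Nc2ccc(F)cc2)cc1` gives 4260 nM
compound 3 `Cc1ccc(S(=O)(=O)/N=C(/CCNC2=CC(=O)c3ccccc3C2=O)Nc2cccc(C)c2)cc1` gives 8120 nM

All three measured compounds share the core and differ only in the aryl group on the amine nitrogen. The steps among them are small: a 1.4-fold lower number from compound 1 to compound 2 (0.15 log units; within the scatter), a 1.3-fold higher number from compound 1 to compound 3 (0.13 log units; within the scatter) and a 1.9-fold higher number from compound 2 to compound 3 (0.28 log units; within the scatter), each within the scatter. Compound 1 stands second highest of the three numbers, with compound 3 nearest and compound 2 furthest, both within the scatter of it. Among the measured compounds shown here, on these numbers no compound can be called more or less potent than another.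

Compound 4 `Cc1ccc(S(=O)(=O)/N=C(/CCNC2=CC(=O)c3ccccc3C2=O)NC2CCCCC2)cc1` differs from compound 1 in one place: cyclohexyl in place of 4-methoxyphenyl on an amine nitrogen. For the measured compounds named here, none of the measured steps swaps an aromatic ring for a non-aromatic one; they only vary substituents on an aromatic ring, and all of them stay within the scatter. Going by the values given here, there is therefore no measured step that bears directly on this change, and the nearest evidence suggests that changes at this position have so far made little difference in this assay.

For compound 4 a number near that of compound 1 is expected, the estimated step being a 1.2-fold higher number from compound 1 to compound 4 (0.09 log units; within the scatter). The estimate for compound 4 in this assay is 7500 nM, within a range of 2500 nM to 22000 nM.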

Compound 4, half-maximal inhibitory concentration: 7580 nM
Beside the measured number, compound 4's estimate is 1.0-fold (0.00 log units) below it; the measured number falls inside the stated range.
By their numbers in this assay, from the lowest: compounds 2, 1, 4 and 3 (each within the scatter of the next).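

In this assay, the aromatic ring on the amine nitrogen turns out not to be required for a number in this range: cyclohexyl in place of 4-methoxyphenyl gives a 1.3-fold higher number from compound 1 to compound 4 (0.10 log units; within the scatter). The comparisons with the other two aryl groups read the same way, with a 1.1-fold lower number from compound 3 to compound 4 (0.03 log units; within the scatter) and a 1.8-fold higher number from compound 2 to compound 4 (0.25 log units; within the scatter), so this position now tolerates a six-membered non-aromatic ring of carbon only, and the loss of the methoxy oxygen's hydrogen-bond acceptor, as well as the substituent swaps seen among compounds 1, 2 and 3. No measurement shown here gives a reason for this insensitivity.

All four groups on this nitrogen are six-membered carbon rings, so it remains open whether a short open chain such as n-butyl, a smaller ring such as cyclopropyl, or a ring carrying a carboxylic acid or a primary amine would also stay within the scatter of these compounds. The rest of the shared core is the same throughout, so these compounds cannot say whether any other part of the structure moves the number in this assay.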